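Chain shortening in nitrooxy carbonates and esters

The compounds below may be only part of what the source reports. "The series", "measured", "known", "first", "only" and "open" are said of these compounds alone.

Three compounds sharing one core are measured in a physicochemical assay for metabolic stability, read by HPLC; on this read-out higher numbers stand for a longer-lived compound and lower numbers for a shorter-lived compound. Compound 1 `Cc1cc(OC(=O)OCCCCCCO[N+](=O)[O-])n(-c2ccccc2)n1` gives 25 h. Compound 2 `Cc1cc(OC(=O)C(C)(C)CO[N+](=O)[O-])n(-c2ccccc2)n1` gives 36 h, and compound 3 `Cc1cc(OC(=O)C(C)(C)CCCCO[N+](=O)[O-])n(-c2ccccc2)n1` gives 22 h. The values of compound 1 and compound 3 lie within the scatter of each other, and so do those of compound 1 and compound 2. How the cores of compound 1 and compound 3 differ is not broken down here.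

Between compound 3 and compound 2 one change is counted: nitrooxy in place of 3-(nitrooxy)propyl on a saturated chain carbon, two bonds along the chain from a carbonyl carbon. That change made a 1.6-fold higher number from compound 3 to compound 2 (0.21 log units; within the scatter).

Compound 4 `Cc1cc(OC(=O)OCCCO[N+](=O)[O-])n(-c2ccccc2)n1` is not yet measured in this assay. It differs from compound 1 by the same kind of change: nitrooxy in place of 3-(nitrooxy)propyl on a saturated chain carbon, three bonds along the chain from an oxygen next to a carbonyl group. The surroundings are not identical, though: in the measured pair the change sits two bonds along the chain from a carbonyl carbon, whereas in compound 4 it sits three bonds along the chain from an oxygen next to a carbonyl group, so it is the same kind of change and not the same one.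

Because a 1.6-fold higher number from compound 3 to compound 2 (0.21 log units; within the scatter) stayed within the scatter, the expected step is a 1.3-fold higher number from compound 1 to compound 4 (0.11 log units; within the scatter), with nothing in the data pointing to more. Starting from compound 1 at 25 h, compound 4 is therefore estimated at 32 h, with a likely range from 18 h to 55 h.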

Compound 4, half-life: 13 h
For compound 4 the middle estimate is 2.5-fold (0.39 log units) above the measured one; measured number outside the range, below it.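

In this assay the new step reads a 1.9-fold lower number from compound 1 to compound 4 (0.28 log units; within the scatter) and now stands as a second reading of nitrooxy in place of 3-(nitrooxy)propyl, alongside a 1.6-fold higher number from compound 3 to compound 2 (0.21 log units; within the scatter) on the other core. Each step stays within the scatter, so neither gives the change a direction on its own core, and the pair shows neither that the change carries from the core of compound 3 to the core of compound 1 nor that it fails to carry; the surroundings of the change also differ between the two pairs, so the two readings are of the same kind of change and not of the same one. Nothing available here bears on a cause for either step.

The compounds shown leave open whether a change of chain length on either core can reach beyond the scatter at all, which a longer chain than 3-(nitrooxy)propyl or (nitrooxy)methyl could help to settle. They also leave open how an amine or a carboxylic acid at the end of the chain, in place of nitrooxy, would read on this half-life measure.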